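The compounds below may be only part of what the source reports. "The series", "measured", "known", "first", "only" and "open" are said of these compounds alone.

Measured compounds in an assay on MDA-MB-231 cells for binding affinity to C-X-C chemokine receptor type 4 (Homo sapiens), read by immunofluorescence and microscopy, with stated times of 10 min and 30 min; on this read-out higher numbers stand for an effect only at larger amounts of compound and lower numbers for an effect already at smaller amounts:
compound 1 `Cc1ccc(S(=O)(=O)NCc2ccc(CNC(=O)c3ccc(F)cc3)cc2)cc1`: 1 nM
compound 2 `Cc1ccc(S(=O)(=O)NCc2ccc(CNC(=O)c3ccc(Cl)cc3)cc2)cc1`: 10 nM
compound 3 `Cc1ccc(S(=O)(=O)NCc2ccc(CNC(=O)c3cccc(C)c3)cc2)cc1`: 1000 nM

Compound 3 gives the highest number of the three, as seen in the steps of a 1000-fold higher number from compound 1 to compound 3 (3.00 log units; beyond the scatter) and a 100-fold higher number from compound 2 to compound 3 (2.00 log units; beyond the scatter). Compound 4 `COc1ccccc1C(=O)NCc1ccc(CNS(=O)(=O)c2ccc(C)cc2)cc1` differs from compound 3 in one place: 2-methoxyphenyl in place of 3-methylphenyl on a carbonyl carbon. Going by the values given here, no measured step covers a 2-methoxyphenyl on the carbonyl carbon, so the direction is uncertain. The two large steps into compound 3 show that exchanging the ring on the carbonyl carbon can move the number strongly, so a sizeable shift either way would not surprise. Compound 4 is expected to give 300 nM, with a range of 20 nM to 5000 nM, an estimated step of a 3.3-fold lower number from compound 3 to compound 4 (0.52 log units; beyond the scatter).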

Compound 4, effective concentration (reported as EC, without a stated level of effect): 100 nM
Estimate against measurement, compound 4: 3.0-fold (0.48 log units) above; low and high end bracket the measured number.
By their numbers in this assay, from the lowest: compound 1; then compound 2; then compound 4; then compound 3.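

In this assay, 2-methoxyphenyl, which carries one hydrogen-bond acceptor where 3-methylphenyl has none, gives a 10-fold lower number from compound 3 to compound 4 (1.00 log units; beyond the scatter) on the carbonyl carbon. It does not match the halogen-bearing rings, with a 10-fold higher number from compound 2 to compound 4 (1.00 log units; beyond the scatter) and with a 100-fold higher number from compound 1 to compound 4 (2.00 log units; beyond the scatter) as well, so a non-halogen ring has now given two different numbers, both higher than those of the halogen-bearing rings. No measured evidence explains these differences. The compounds shown leave open how a ring bearing an amine or a carboxylic acid would read here. They also leave open whether the methoxy group itself or its place on the ring sets the number.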